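Swapping a methylphenyl arm for a cyclohexenyl ring

A few compounds are considered here, and "the series" means these few. Any claim that something is new, unique, unknown or untested is made for them only; others in the source may bear on it.

Compound 1 `CC(C)(C)c1ccc(-c2cn(C/C=C3\OC(=O)C(OCc4ccccc4)=C3OCc3ccccc3)nn2)cc1` and compound 2 `Cc1ccc(-c2cn(C/C=C3\OC(=O)C(OCc4ccccc4)=C3OCc3ccccc3)nn2)cc1` share one core. In a functional assay on MDA-MB-231 cells (Homo sapiens) for antiproliferative activity, read by MTT assay, with a stated time of 24 h (on this read-out lower numbers stand for stronger inhibition and higher numbers for weaker inhibition), compound 1 gives 51200 nM. For compound 2 this assay reports only a limit, > 100000 nM. Going by the values given here, the step of an at least 1.9-fold higher number from compound 1 to compound 2 (0.29 log units; that floor lies within the scatter) leaves compound 2 sitting at the limit of > 100000 nM in this assay, at which 1 of the 2 values shown sits, the sole such value among the two measured. Compound 3 `O=C1O/C(=C\Cn2cc(C3=CCCCC3)nn2)C(OCc2ccccc2)=C1OCc1ccccc1` differs from compound 2 by cyclohex-1-en-1-yl in place of 4-methylphenyl on an aromatic carbon. Among the compounds with values here, no measured step covers this kind of exchange, and the single known step was small, so no change beyond the scatter is expected: the estimated step is a number no higher from compound 2 to compound 3 (the limit leaves the size open). Compound 3 is therefore expected near 100000 nM, within 35000 nM to 300000 nM.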

Compound 3, half-maximal inhibitory concentration: > 100000 nM
Compound 3: no number, only a limit; the forecaster's own chance of this, stated with the estimate: 55%; the middle value sits exactly at the limit.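

With cyclohex-1-en-1-yl in place of 4-methylphenyl, compound 3 also gives only a limit in this assay, as compound 2 does, so the step between them cannot be read. Going by these compounds alone, the one readable step is an at least 1.9-fold higher number from compound 1 to compound 3 (0.29 log units; that floor lies within the scatter). A non-aromatic ring at this place therefore yields no number here, and the limit now holds most of the series: the limit of > 100000 nM in this assay, at which 2 of the 3 values shown sit.

From the compounds shown here alone, how far compound 2 and compound 3 lie past that limit stays open. So does whether an amine or a carboxylic acid on the cyclohexenyl ring would give a readable number.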